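The source may hold more compounds than are shown below. What is called first, only, known or untested is meant among the compounds shown, and "the series" means these compounds.

Measured compounds and their values in this assay:

- compound 1, `C[C@@H]1CCC[C@H](C)N1CCCCNC(=O)c1cc(Cl)ccc1O`: 100 ug/mL
- compound 2, `C[C@@H]1CCC[C@H](C)N1CCCNC(=O)c1cc(Cl)ccc1O`: 30 ug/mL
- compound 3, `Cc1ccc(O)c(C(=O)NCCCN2CCC[C@@H]3CCCC[C@@H]32)c1`: > 100 ug/mL

All three were tested in a functional assay on MDBK cells (Bos taurus) for cytotoxicity; on this read-out lower numbers stand for higher toxicity in this test and higher numbers for lower toxicity in this test. Compound 3 stands apart from the others in that its result is not a number but a limit: in this assay compound 3 gives > 100 ug/mL, which is the limit of > 100 ug/mL in this assay, at which 1 of the 3 values shown sits. Compound 4, `O=C(NCCCN1CCC[C@@H]2CCCC[C@@H]21)c1cc(Cl)ccc1O`, has not yet been measured. It differs from compound 3 in one place only, (chloro in place of methyl on an aromatic carbon), that is, chloro in place of methyl on an aromatic carbon. Going by the values given here, no measured pair shows this exact exchange, so there is no measured step to lean on. Compound 1 and compound 2 both carry the chloro on the same kind of ring, yet differ from compound 4 elsewhere, so their values only show that such chloro compounds can sit near the top of the range measured here: in this assay compound 1 gives 100 ug/mL, and compound 2 gives 30 ug/mL. For compound 4 a step from compound 3 toward a somewhat lower number is expected, an at least 1.4-fold lower number from compound 3 to compound 4 (0.15 log units; that floor lies within the scatter), not far beyond the usual scatter. Compound 4 is therefore estimated at 70 ug/mL, with a likely range from 25 ug/mL to 150 ug/mL, and a fair chance that only a limit is reported again.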

Compound 4, half-maximal cytotoxic concentration: 43 ug/mL
Estimate against measurement, compound 4: 1.6-fold (0.21 log units) above; the range from low to high includes it.
By their numbers in this assay, from the lowest: compounds 2 and 4 (each within the scatter of the next); then compound 1.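

In this assay, putting chloro in place of methyl on the aromatic carbon para to a hydroxy group gives an at least 2.3-fold lower number from compound 3 to compound 4 (0.36 log units; beyond the scatter), so this position of the ring does affect the result. The earlier compounds shown here could not show this: compound 1 and compound 2 both carry the chloro, but neither has a methyl partner that differs from it in this one place only. Compound 3 gives > 100 ug/mL, which is a limit and not a number, so the step gives only a minimum size and its full size stays unknown: the limit of > 100 ug/mL in this assay, at which 1 of the 4 values shown sits.

The compounds shown leave open how other groups at this position, such as fluoro, methoxy or an amine, would compare with methyl and chloro. They also leave open whether the same exchange would give a similar step on the cores of compound 1 and compound 2.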